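Halogen pattern on the aryl group of compound 4

The compounds below may be only part of what the source reports. "The series", "measured", "known", "first", "only" and "open" are said of these compounds alone.

Compound 3 `Cn1ccc2c(Oc3ccc(NC(=O)c4cc5cccnc5n(-c5ccc(Cl)cc5)c4=O)cc3F)ccnc21` gives 220 nM in a functional assay on HT-29 cells (Homo sapiens) for antiproliferative activity, read by MTT assay, with a stated time of 72 h (a lower number here means a stronger inhibitor, a higher number a weaker inhibitor), the highest of the three numbers measured. Compound 2 `Cn1ccc2c(Oc3ccc(NC(=O)c4cc5cccnc5n(-c5ccc(F)cc5)c4=O)cc3F)ccnc21` gives 160 nM and compound 1 `O=C(Nc1ccc(Oc2ccnc3[nH]ccc23)c(F)c1)c1cc2cccnc2n(-c2ccc(Cl)cc2)c1=O` gives 82 nM in this assay. For the measured compounds named here, the change a 2.7-fold higher number from compound 1 to compound 3 (0.43 log units; beyond the scatter) was the only step beyond the scatter, whereas a 1.4-fold higher number from compound 2 to compound 3 (0.14 log units; within the scatter) stayed within it. Compound 4 `Cn1ccc2c(Oc3ccc(NC(=O)c4cc5cccnc5n(-c5ccc(F)c(Cl)c5)c4=O)cc3F)ccnc21` differs from compound 3 by 3-chloro-4-fluorophenyl in place of 4-chlorophenyl on an aromatic nitrogen. The step that bears on this change is the halogen exchange at the same place, a 1.4-fold higher number from compound 2 to compound 3 (0.14 log units; within the scatter), which was small; the methyl step concerns a different part of the shared core. The expectation is therefore for a step of a 1.1-fold lower number from compound 3 to compound 4 (0.04 log units; within the scatter), within the scatter. Compound 4 is expected to give 200 nM in this assay, with a range of 90 nM to 450 nM.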

Compound 4, half-maximal inhibitory concentration: 2460 nM
Estimate against measurement, compound 4: 12-fold (1.09 log units) below; measured number above the stated range.
By their numbers in this assay, from the lowest: compounds 1, 2 and 3 (each within the scatter of the next, the first and the last beyond it); then compound 4.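

Chloro in place of hydrogen on an aromatic carbon of the aryl group gave a 15-fold higher number from compound 2 to compound 4 (1.19 log units; beyond the scatter), and 3-chloro-4-fluorophenyl in place of 4-chlorophenyl gave an 11-fold higher number from compound 3 to compound 4 (1.05 log units; beyond the scatter) in this assay. This group on the aromatic nitrogen therefore tolerated the exchange of one halogen for another, but not the second halogen present in compound 4. Nothing available explains this loss. On these data alone, it remains open whether the loss follows from the chloro group alone or from the two halogens together, and how a methoxy group or an amine would fare on this aryl group.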